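The source may report more compounds than this note shows. Statements on the series, on what has been measured and on what is new or still open speak of the compounds shown alone.

Of the compounds shown here, two built on the same core have been measured in a functional assay on P388 cells (Mus musculus) for cytotoxicity, read by MTT assay, with a stated time of 72 h; on this read-out higher numbers stand for weaker inhibition and lower numbers for stronger inhibition. Compound 1 `Cc1c(/N=C/c2ccc(N(C)C)cc2)c(=O)n(-c2ccccc2)n1C` gives 468000000 nM in this assay, and compound 2 `CCOc1cccc(/C=N/c2c(C)n(C)n(-c3ccccc3)c2=O)c1` gives 295000000 nM in this assay. Compound 1 has the higher of the two numbers, yet the gap to compound 2 lies within the usual scatter of repeated measurements, so the two compounds cannot be told apart on these data; both sit at the weak end of what this assay reports.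

Compound 3 `COc1ccc(/C=N/c2c(C)n(C)n(-c3ccccc3)c2=O)cc1` has not yet been measured in this assay. It differs from compound 1 in one place: methoxy in place of dimethylamino on an aromatic carbon. Within the data shown here, no step between measured compounds covers this change, so there is nothing in the data to anchor a direction. Given that compound 1 shows 468000000 nM and compound 2, carrying a different substituent on the same kind of ring, shows 295000000 nM, the step from compound 1 to compound 3 is expected to be a 1.2-fold lower number from compound 1 to compound 3 (0.07 log units; within the scatter), none beyond the scatter. Compound 3 is therefore expected to give about 400000000 nM in this assay, with a likely range from 120000000 nM to 1300000000 nM.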

Compound 3, half-maximal inhibitory concentration: 186000000 nM
The estimate for compound 3 lay 2.2-fold (0.33 log units) above the measured number; the measured number falls inside the stated range.
By their numbers in this assay, from the lowest: compounds 3, 2 and 1 (each within the scatter of the next, the first and the last beyond it).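

Exchanging dimethylamino for methoxy on the aromatic carbon para to a large group gives a 2.5-fold lower number from compound 1 to compound 3 (0.40 log units; beyond the scatter) in this assay, the first single-place step available in this set and one that shows this position responds to a change of substituent. The response is modest, and with compound 3 at 186000000 nM the number remains very high, so the exchange of one neutral group for another, each with one hydrogen-bond acceptor, adjusts weak inhibition without turning it into strong inhibition. No measurement here explains why the number moves with this change.

On these data alone, it remains open whether other groups on this carbon, such as a hydroxyl, a chlorine, a nitrile or a longer alkoxy chain, would lower the number further or return it towards that of compound 1. Also unresolved is where the plain ring with only hydrogen on this carbon would fall relative to compound 1 and compound 3, and whether methoxy on another carbon of the ring would produce a similar shift.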